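Benzyl ether variation on the shared anilide core

This account rests on a few compounds, and the source may have more. Where it says the series, first, only, none or still open, it means among the compounds named here.

Within the data shown here, compound 1 `N#Cc1ccccc1COc1ccccc1C(=O)Nc1cccnc1` stands as the weaker of the two compounds measured so far: in an assay on lysate for inhibition of phosphatidylcholine:ceramide cholinephosphotransferase 2 (Homo sapiens), read by HPLC, with stated times of 30 min and 2 h (on this read-out lower numbers stand for stronger inhibition and higher numbers for weaker inhibition), compound 1 gives 31800 nM, the highest number of the pair. Its nearest neighbour is compound 2 `O=C(Nc1cccnc1)c1ccccc1OCc1cccc(Cl)c1F`, which in this assay gives 3100 nM. The step between them, a 10-fold lower number from compound 1 to compound 2 (1.01 log units; beyond the scatter), exchanges the 2-cyanophenyl for a 3-chloro-2-fluorophenyl on the saturated chain carbon bound to an oxygen on the aromatic ring.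

Compound 3 `Cc1ccc(F)cc1COc1ccccc1C(=O)Nc1cccnc1` alters the same place: 5-fluoro-2-methylphenyl in place of 2-cyanophenyl on a saturated chain carbon bound to an oxygen on an aromatic ring. Among the measured compounds shown here, the only measured step bearing on this change is the one from compound 1 to compound 2, and it was large. Compound 3 resembles compound 2 in replacing the 2-cyanophenyl with a substituted phenyl that no longer carries the nitrile, so a drop in the number of the same kind is expected, its size uncertain with a single step as guide. Because compound 2 gave 3100 nM, compound 3 is expected to fall closer to compound 2 than to compound 1, with a step of a 5.3-fold lower number from compound 1 to compound 3 (0.72 log units; beyond the scatter) expected. The estimate for compound 3 in this assay is 6000 nM, within a range from 2000 nM to 20000 nM.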

Compound 3, half-maximal inhibitory concentration: 740 nM
Beside the measured number, compound 3's estimate is 8.1-fold (0.91 log units) above it, and the stated range ends above it.
By their numbers in this assay, from the lowest: compound 3; then compound 2; then compound 1.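

In this assay, among these compounds, the place on a saturated chain carbon bound to an oxygen on an aromatic ring now shows a wider span than the single earlier step revealed: a 43-fold lower number from compound 1 to compound 3 (1.63 log units; beyond the scatter) marks 5-fluoro-2-methylphenyl as the replacement for 2-cyanophenyl that gives the lowest number of the three. Both replacements without the nitrile lie below compound 1, but they also separate from each other, with a 4.2-fold lower number from compound 2 to compound 3 (0.62 log units; beyond the scatter) showing that removal of the nitrile does not alone fix the number and that the entering substituted phenyl also matters. No measurement at hand accounts for the difference among these three groups.

The compounds shown leave open how much of the gain belongs to the methyl and how much to the fluorine of 5-fluoro-2-methylphenyl, and where a plain unsubstituted phenyl would fall in this order. Also open, on these data alone, is how this place would respond to a phenyl carrying an aminomethyl group or a carboxylic acid, or to a longer chain in place of the single saturated chain carbon.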